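Swapping Thiophene for Pyridine: Solubility Expected to Return

This account rests on a few compounds, and the source may have more. Where it says the series, first, only, none or still open, it means among the compounds named here.

Compound 1 `CCCOc1ccc(C[C@@H](Cc2ccccc2)C(=O)O)cc1CNC(=O)c1ccc(-c2ccncc2)cc1` and compound 2 `CCCOc1ccc(C[C@@H](Cc2ccccc2)C(=O)O)cc1CNC(=O)c1ccc(-c2cccs2)cc1` share one core and differ only in the aromatic ring at the end of the amide. In a physicochemical assay for solubility, read by HPLC, in phosphate buffer, measured as thermodynamic solubility, with a stated time of 48 h, at pH 7.2 (on this read-out higher numbers stand for higher solubility and lower numbers for lower solubility), compound 1 gives 34.1 ug/mL. Compound 2 in this assay reaches only a limit, < 1 ug/mL, and so stands at the low end of the values shown (the limit of < 1 ug/mL in this assay, at which 1 of the 2 values shown sits). The step of an at least 34-fold lower number from compound 1 to compound 2 (1.53 log units; beyond the scatter) was large. Compound 3 `CCCOc1ccc(C[C@@H](Cc2ccccc2)C(=O)O)cc1CNC(=O)c1ccc(-c2ccccn2)cc1` carries the change (pyridin-2-yl in place of thiophen-2-yl on an aromatic carbon), which largely reverses that step, bringing pyridin-2-yl rather than the pyridin-4-yl of compound 1, so a large rise is expected. Compound 3 is estimated at 10 ug/mL, between 1 ug/mL and 40 ug/mL, a step of an at least 10-fold higher number from compound 2 to compound 3 (1.00 log units; beyond the scatter).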

Compound 3, solubility: 17 ug/mL
Estimate against measurement, compound 3: 1.7-fold (0.23 log units) below, within the range that was stated.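

In this assay, pyridin-2-yl in place of thiophen-2-yl gives an at least 17-fold higher number from compound 2 to compound 3 (1.23 log units; beyond the scatter), so a large step at this position is not tied to pyridin-4-yl alone. Pyridin-2-yl in place of pyridin-4-yl gives a 2.0-fold lower number from compound 1 to compound 3 (0.30 log units; within the scatter), so the two rings cannot be told apart here. The value of compound 2 is a limit and not a number: the limit of < 1 ug/mL in this assay, at which 1 of the 3 values shown sits.

Going by these compounds, how pyridin-3-yl or a plain phenyl would read at this position remains open. The compounds shown also cannot separate the role of the ring nitrogen from that of ring size.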